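Replacing 4-aminophenyl with 2-aminoethyl: an expected cytotoxicity value

The source may report more compounds than this note shows. Statements on the series, on what has been measured and on what is new or still open speak of the compounds shown alone.

Measured in a functional assay on MDA-MB-435 cells (Homo sapiens) for cytotoxicity, read by MTT assay, with a stated time of 72 h; a higher number here means a weaker inhibitor, a lower number a stronger inhibitor:
Compound 1 `Nc1ccc(Nc2c(C(=O)NCc3ccc(F)cc3)nc(Br)c3cccnc23)cc1`: 7000 nM
Compound 2 `COc1ccc(CNC(=O)c2nc(Br)c3cccnc3c2N[C@H]2CC[C@H](N)CC2)cc1`: 5000 nM
Compound 3 `CN(C)c1ccc(CNC(=O)c2nc(Br)c3cccnc3c2N[C@H]2CC[C@H](N)CC2)cc1`: 4000 nM

Compound 1 stands within the usual scatter of both compound 2 and compound 3. The unmeasured compound 4 `NCCNc1c(C(=O)NCc2ccc(F)cc2)nc(Br)c2cccnc12` alters compound 1 in one place: 2-aminoethyl in place of 4-aminophenyl on a nitrogen on an aromatic ring. Here, 2-aminoethyl takes the place of 4-aminophenyl on a nitrogen on an aromatic ring. Within the data shown here, the only measured step, a 1.3-fold lower number from compound 2 to compound 3 (0.10 log units; within the scatter), swaps methoxy for dimethylamino and lies within the scatter. Among the measured compounds shown here, it is a different change, so it offers only weak guidance, and no measured step tests this swap directly. No shift beyond the scatter is therefore expected in this assay. The expected step is a 1.4-fold lower number from compound 1 to compound 4 (0.15 log units; within the scatter). The expected value for compound 4 is 5000 nM, with an estimated range of 1500 nM to 15000 nM.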

Compound 4, half-maximal inhibitory concentration: 12000 nM
Estimate against measurement, compound 4: 2.4-fold (0.38 log units) below; the measured number falls inside the stated range.
By their numbers in this assay, from the lowest: compounds 3, 2, 1 and 4 (each within the scatter of the next, the first and the last beyond it).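

In this assay, among these compounds, the new step reads a 1.7-fold higher number from compound 1 to compound 4 (0.23 log units; within the scatter), the first measured change of the group on this nitrogen. The 4-aminophenyl group, with its six-membered aromatic ring, gives way to the smaller 2-aminoethyl, which has no ring, and the number stays within the scatter, so this ring is not needed to keep cytotoxicity at this level. Nothing available explains this outcome. Still open, from the compounds shown here alone, is whether a longer chain, such as 3-aminopropyl, or a 2-hydroxyethyl group, which carries a hydroxyl instead of the amine, would move the number beyond the scatter.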